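Swapping Oxan-4-yl for Cyclobutylmethyl on an Amide-Type Nitrogen

The source may hold more compounds than are shown below. What is called first, only, known or untested is meant among the compounds shown, and "the series" means these compounds.

Compound 1 `O=C(CN(CC1CC1)C(=O)c1ccc(-c2ccccn2)cc1)Nc1cc(F)cc(F)c1`: 25 ug/mL
Compound 2 `O=C(CN(C(=O)c1ccc(-c2ccccn2)cc1)C1CCOCC1)Nc1cc(F)cc(F)c1`: 99 ug/mL
Compound 3 `O=C(CN(CC1CCC1)C(=O)c1ccc(-c2ccccn2)cc1)Nc1cc(F)cc(F)c1`: not yet measured

Among the measured compounds shown here, in a physicochemical assay for solubility, read by chemiluminescence (a lower number here means a less soluble compound, a higher number a more soluble compound), compound 2 gives 99 ug/mL and holds the higher of the only two numbers so far.

Compound 3 differs from compound 2 at one place, with cyclobutylmethyl in place of oxan-4-yl on an amide-type nitrogen. For the measured compounds named here, one measured step bears on this change. Going from cyclopropylmethyl to oxan-4-yl at that same nitrogen gave a 4.0-fold higher number from compound 1 to compound 2 (0.60 log units; beyond the scatter) and was a modest change. Compound 3 removes oxan-4-yl again, so that step read backwards is the best available guide. Going by the values given here, it is thin evidence, since no measured compound carries cyclobutylmethyl. A fall of similar size in this assay is therefore expected, beyond the scatter, and the estimated step is a 4.5-fold lower number from compound 2 to compound 3 (0.65 log units; beyond the scatter) in this direction. The estimate for compound 3 is 22 ug/mL with an expected range from 8 ug/mL to 50 ug/mL on this reading.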

Compound 3, solubility: 7 ug/mL
Compound 3: the middle estimate sits 3.1-fold (0.50 log units) above what was measured; measured number outside the range, below it.
By their numbers in this assay, from the lowest: compound 3; then compound 1; then compound 2.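

In this assay, among the compounds shown here, replacing oxan-4-yl with cyclobutylmethyl on the amide-type nitrogen is a large step (a 14-fold lower number from compound 2 to compound 3 (1.15 log units; beyond the scatter)), whereas the one earlier step at this nitrogen was modest (a 4.0-fold higher number from compound 1 to compound 2 (0.60 log units; beyond the scatter)). The new compound also shows that this position responds even when the group stays all carbon: putting cyclobutyl in place of cyclopropyl on the saturated chain carbon bound to that nitrogen still gives a step beyond the scatter (a 3.6-fold lower number from compound 1 to compound 3 (0.55 log units; beyond the scatter)), so the two carbon-only groups cannot be treated as interchangeable here. Among these three compounds, the one carrying a ring oxygen holds the highest number, but nothing shown explains why the numbers move as they do.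

Oxan-4-yl and cyclobutylmethyl differ in several ways at once, including ring size, the ring oxygen and the chain carbon that links the ring to the nitrogen, so these compounds cannot say which difference matters. A cyclohexyl group, an oxan-4-ylmethyl group or a piperidin-4-yl group with a ring nitrogen would each separate part of that question, and the shared core might not respond in the same way to any of them.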